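Sulfonyl aryl swap in a fluorinated pyridyl pyrrole series

A few compounds are considered here, and "the series" means these few. Any claim that something is new, unique, unknown or untested is made for them only; others in the source may bear on it.

Measured compounds:
compound 1 `CNCc1cn(S(=O)(=O)c2ccoc2)c(-c2cccnc2F)c1F`: 95%
compound 2 `CNCc1cn(S(=O)(=O)c2ncccc2C)c(-c2cccnc2F)c1F`: 54%

In a functional assay on the whole organism (strain Jcl:Sprague-Dawley) for inhibition, with Rattus norvegicus as the target, with stated times of 3 min and 3 h, at a dose of 1 mg/kg by the intravenous route (on this read-out higher numbers stand for more inhibition at the one dose given (going by the name of the read-out) and lower numbers for less inhibition), compound 2 stands lowest of the two numbers; the nearest is compound 1, and the step of a number 41 percentage points lower from compound 1 to compound 2 (beyond the scatter) is large. Compound 3 `CNCc1cn(S(=O)(=O)c2ccc(F)cn2)c(-c2cccnc2F)c1F` differs from compound 2 by 5-fluoropyridin-2-yl in place of 3-methylpyridin-2-yl on a sulfonyl sulfur. Among the compounds with values here, no measured step covers this exact change; the only related step, from compound 1 to compound 2, shows that the group on the sulfonyl sulfur can move the number strongly. Compound 3 is therefore expected to lie at 65%, between 35% and 95%, a step of a number 11 percentage points higher from compound 2 to compound 3 (beyond the scatter) that is uncertain in direction.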

Compound 3, a percentage reported as inhibition, in the whole organism at one dose (the size of the read-out at that dose, not a potency): 87%
For compound 3 the middle estimate is 22 percentage points below the measured one; measured number inside the range.
By their numbers in this assay, from the lowest: compound 2; then compounds 3 and 1 (each within the scatter of the next).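

At this sulfonyl sulfur, the low number does not follow from a pyridine ring as such: in this assay, keeping the ring but using 5-fluoropyridin-2-yl in place of 3-methylpyridin-2-yl gives a number 33 percentage points higher from compound 2 to compound 3 (beyond the scatter), a large recovery. Against the furan-3-yl group, the result is a number 8 percentage points lower from compound 1 to compound 3 (within the scatter), so a five-membered and a six-membered aromatic ring can both give high numbers here. No evidence on the cause of either step is available. The two pyridine groups differ in both substituent and its location, so these compounds cannot separate those effects. From the compounds shown here alone, how an unsubstituted pyridin-2-yl or a methoxy-bearing pyridine would read remains open.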